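Swapping chloro for fluoro on the benzyl of compound 3

The source may report more compounds than this note shows. Statements on the series, on what has been measured and on what is new or still open speak of the compounds shown alone.

Compound 3 `OCCNc1nc(-c2ccccc2)nc2c1nnn2Cc1ccccc1Cl` gives 116 nM in an assay on Cerebral cortex for displacement of a labelled ligand from adenosine receptor A1 (Bos taurus) (a lower number here means a stronger inhibitor, a higher number a weaker inhibitor), the highest of the three numbers shown; compound 1 `CCCNc1nc(-c2ccccc2)nc2c1nnn2Cc1ccccc1F` gives 3.2 nM and compound 2 `Fc1ccccc1Cn1nnc2c(NC3CCCCC3)nc(-c3ccccc3)nc21` gives 1.15 nM. For the measured compounds named here, the one measured step, a 2.8-fold lower number from compound 1 to compound 2 (0.44 log units; beyond the scatter), changes the group on the nitrogen, not the benzyl, so it does not bear on the change considered here. Compound 4 `OCCNc1nc(-c2ccccc2)nc2c1nnn2Cc1ccccc1F` differs from compound 3 only by fluoro in place of chloro on an aromatic carbon. Going by the values given here, no measured pair isolates this halogen swap, and nothing here separates the benzyl change from the amino change. Compound 4 is therefore expected to show a step of a 1.2-fold lower number from compound 3 to compound 4 (0.06 log units; within the scatter) in this assay, not beyond the scatter. Compound 4 is estimated at 100 nM, within 40 nM to 250 nM.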

Compound 4, inhibition constant: 54 nM
Compound 4: middle estimate off by 1.9-fold (0.27 log units), on the high side; the measured number falls inside the stated range.
By their numbers in this assay, from the lowest: compound 2; then compound 1; then compound 4; then compound 3.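

In this assay, with the 2-hydroxyethyl group held fixed, the change from 2-chlorobenzyl to 2-fluorobenzyl gives a 2.1-fold lower number from compound 3 to compound 4 (0.33 log units; beyond the scatter), a modest step that shows this halogen swap is readable at this position. The group on the nitrogen matters far more, with a 47-fold higher number from compound 2 to compound 4 (1.67 log units; beyond the scatter) and a 17-fold higher number from compound 1 to compound 4 (1.23 log units; beyond the scatter). Nothing available here explains these steps. Going by these compounds, whether bromo or methyl on this aromatic carbon would continue the trend remains open. So does whether the halogen step holds alongside the propyl or cyclohexyl groups.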